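The compounds below may be only part of what the source reports. "The series", "measured", "known", "first", "only" and "open" are said of these compounds alone.

Compound 1 `O=C(NC1CC1)c1ccc(F)c(NCc2cnc(Nc3ccccn3)s2)c1` sits at a limit of the assay in a functional assay on L2987 cells (Homo sapiens) for antiproliferative activity; a lower number here means a stronger inhibitor, a higher number a weaker inhibitor: compound 1 gives > 2500 nM. Compound 2 `O=C(NC1CC1)c1ccc(F)c(CCc2cnc(Nc3ccccn3)s2)c1` likewise reaches only a limit, giving > 2500 nM in this assay. Both values shown sit at the limit of > 2500 nM in this assay, at which 2 of the 2 values shown sit, so compound 1 cannot be ranked against anything measured. Compound 3 `O=C(NCc1ccccc1)c1ccc(F)c(NCc2cnc(Nc3ccccn3)s2)c1` differs from compound 1 by benzyl in place of cyclopropyl on an amide-type nitrogen. Among the measured compounds shown here, no measured step covers this change, and the step that the limit leaves unreadable from compound 1 to compound 3 is expected to stay within the scatter, with no anchor to say otherwise. Compound 3 is therefore estimated at 4000 nM, in a range from 1500 nM to 12000 nM, most likely reported again only as a limit.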

Compound 3, half-maximal inhibitory concentration: > 2500 nM
Compound 3 ended at the assay's limit (the forecaster's own chance of this, stated with the estimate: 70%); the middle value does not contradict the limit.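

Among the compounds shown here, no step from compound 1 to compound 3 can be read, since both stand only at a limit: the limit of > 2500 nM in this assay, at which 3 of the 3 values shown sit. The compounds shown leave open how benzyl and cyclopropyl on the amide-type nitrogen actually compare in this assay.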